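Methoxy to hydroxy: cytotoxicity notes on the series

The source may hold more compounds than are shown below. What is called first, only, known or untested is meant among the compounds shown, and "the series" means these compounds.

The series shares one core; compound 3 is `COc1cccc(-c2ccc(C(=O)N(Cc3cccc(OCCCCCC(=O)O)c3)C(C)C)cc2)c1`, compound 1 is `CC(=O)Nc1cccc(-c2ccc(C(=O)N(Cc3cccc(OCCCCCC(=O)O)c3)C(C)C)cc2)c1` and compound 2 is `CC(C)COc1cccc(-c2ccc(C(=O)N(Cc3cccc(OCCCCCC(=O)O)c3)C(C)C)cc2)c1`. In an ADME assay on HepG2 cells (Homo sapiens) for cytotoxicity, read by CellTiter-Glo and resazurin assay, with a stated time of 72 h (on this read-out lower numbers stand for an effect already at smaller amounts and higher numbers for an effect only at larger amounts of compound), compound 3 gives only a limit, > 26000 nM. Compound 1 likewise gives only a limit, > 26000 nM. Compound 2 also gives only a limit, > 26000 nM. All three therefore stand together at the limit of > 26000 nM in this assay, at which 3 of the 3 values shown sit, and the steps between them cannot be sized: a step that the two limits leave unreadable from compound 1 to compound 2, a step that the two limits leave unreadable from compound 1 to compound 3 and a step that the two limits leave unreadable from compound 2 to compound 3 all remain unreadable.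

Compound 4 is `CC(C)N(Cc1cccc(OCCCCCC(=O)O)c1)C(=O)c1ccc(-c2cccc(O)c2)cc1`. It differs from compound 3 by hydrogen in place of methyl on an oxygen on an aromatic ring. Among the measured compounds shown here, no measured step covers this exact change; the three steps that alter the group on the same aromatic ring (acetamido, isobutoxy, methoxy) were all unreadable between limits, so they give neither a size nor a direction. With every measured compound at the limit, the expectation for this assay is no step beyond the scatter, and the step from compound 3 to compound 4 is estimated as a step that the limit leaves unreadable from compound 3 to compound 4. Compound 4 is expected to give 30000 nM, with a range from 13000 nM to 80000 nM, and is most likely to be reported again only as a limit.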

Compound 4, half-maximal effective concentration: > 26000 nM
Compound 4 was reported as a limit; the forecaster's own chance of this, stated with the estimate: 85%; the middle value lies beyond the limit too.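

In this assay compound 4 also gives > 26000 nM as a limit. Among the compounds shown here, no step from compound 1, compound 2 or compound 3 to compound 4 can be read, and all four compounds stand together: the limit of > 26000 nM in this assay, at which 4 of the 4 values shown sit.

The compounds shown leave open where any of them would reach a half-maximal effect, and whether methoxy to hydroxy alters it.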